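Replacing 4-methylphenyl with phenoxymethyl: notes on compound 4

The source may hold more compounds than are shown below. What is called first, only, known or untested is meant among the compounds shown, and "the series" means these compounds.

Measured in an ADME assay on MRC5 cells (Homo sapiens) for cytotoxicity, read by MTT assay, with a stated time of 72 h; a lower number here means a stronger inhibitor, a higher number a weaker inhibitor:
- compound 1 `O=C(Nc1nnc(-c2cccc(O)c2O)s1)c1ccc(Cl)cc1`: 18700 nM
- compound 2 `O=C(COc1ccccc1)Nc1nnc(-c2cccc(O)c2O)s1`: 33900 nM
- compound 3 `Cc1ccc(C(=O)Nc2nnc(-c3ccc(O)c(O)c3)s2)cc1`: 27100 nM

Compound 3 lies within the scatter of both other compounds, and the three values do not separate. Compound 4 `O=C(COc1ccccc1)Nc1nnc(-c2ccc(O)c(O)c2)s1` carries phenoxymethyl in place of 4-methylphenyl on a carbonyl carbon. The closest measured change is a 1.8-fold higher number from compound 1 to compound 2 (0.26 log units; within the scatter), which brings in the same phenoxymethyl but replaces 4-chlorophenyl on the core of compound 1. That single step gives only a weak hint of direction. In this assay, no shift beyond the scatter is expected, and the estimated step is a 1.3-fold higher number from compound 3 to compound 4 (0.11 log units; within the scatter). For compound 4 the estimated value is 35000 nM, with an expected range of 18000 nM to 65000 nM.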

Compound 4, half-maximal inhibitory concentration: 30900 nM
Compound 4: the middle estimate sits 1.1-fold (0.05 log units) above what was measured, within the range that was stated.
By their numbers in this assay, from the lowest: compounds 1, 3, 4 and 2 (each within the scatter of the next).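

In this assay, phenoxymethyl in place of 4-methylphenyl on a carbonyl carbon now has a direct reading a 1.1-fold higher number from compound 3 to compound 4 (0.06 log units; within the scatter) that does not separate the two groups. Among the compounds shown here, the first matched pair for 3,4-dihydroxyphenyl in place of 2,3-dihydroxyphenyl on an aromatic carbon gives a 1.1-fold lower number from compound 2 to compound 4 (0.04 log units; within the scatter) and does not separate those groups either. No supporting data bear on these results.

From the compounds shown here alone, whether an amine or a carboxylic acid in place of phenoxymethyl on the carbonyl carbon would give a step beyond the scatter remains open.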